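The source may hold more compounds than are shown below. What is called first, only, known or untested is meant among the compounds shown, and "the series" means these compounds.

Working notes on the series in a functional assay on A549 cells (Homo sapiens) for inhibition, read by MTT assay, with a stated time of 72 h; a higher number here means a weaker inhibitor, a lower number a stronger inhibitor. Compound 1 (`COc1cc(O)c(CC=C(C)C)c(O)c1C(=O)/C=C/c1ccc([N+](=O)[O-])cc1`) gives 31200 nM, and compound 2 (`COc1cc(O)cc(O)c1C(=O)/C=C/c1ccc(Cl)cc1`) gives 18200 nM. Compound 3 (`COc1cc(OC)c(C(=O)/C=C/c2ccc(O)cc2)c(OC)c1`) gives 49400 nM, which lies within the scatter of compound 1 and is weaker than compound 2 by more than the scatter. Compound 4 (`COc1cc(OC)c(C(=O)/C=C/c2ccc(N)cc2)c(OC)c1`) is compound 3 altered at a single place: amino in place of hydroxy on an aromatic carbon, para to a large group. Among the measured compounds shown here, no measured pair here isolates a single change, so the data give no direct guide to this step. A small move toward a stronger result is expected in this assay, with the estimated step of a 1.6-fold lower number from compound 3 to compound 4 (0.22 log units; within the scatter) staying within the scatter. For compound 4 the estimate is 30000 nM, with an expected range of 12000 nM to 70000 nM.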

Compound 4, half-maximal inhibitory concentration: > 50000 nM
Compound 4: only a limit was reported; the forecaster's own chance of this, stated with the estimate: 10%; middle value at least 1.6-fold (0.22 log units) away from the limit.
By their numbers in this assay, from the lowest: compounds 2, 1 and 3 (each within the scatter of the next, the first and the last beyond it). At a limit, above all of these: compound 4.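

Among the compounds shown here, for the change from 4-hydroxyphenyl to 4-aminophenyl, the first pair that differs in one place gives an at least 1.0-fold higher number from compound 3 to compound 4 (0.00 log units; that floor lies within the scatter), a step bounded on one side only. In this assay compound 4 is reported as a limit and not as a number: the limit of > 50000 nM in this assay, at which 1 of the 4 values shown sits.

Amino in place of hydroxy at this place, para to a large group, therefore gives no stronger result here, and the true size of the step cannot be read. On these data alone, what a carboxylic acid or an acetamide would give at this place stays open, as does whether the same change behaves alike on the core of compound 2.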